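This account rests on a few compounds, and the source may have more. Where it says the series, first, only, none or still open, it means among the compounds named here.

Measured compounds and their values:

compound 1, `CCCCCCC#Cc1cc2cn([C@@H]3O[C@H](CO)[C@@H](O)[C@H]3O)c(=O)nc2o1`, gives >= 133000 nM
compound 2, `CCCCCCC#Cc1cc2cn(C)c(=O)nc2o1`, gives 194000 nM
compound 3, `CCCCCCCCC#Cc1cc2cn([C@@H]3O[C@H](CO)[C@@H](O)[C@H]3O)c(=O)nc2o1`, gives 49000 nM

All three were tested in a functional assay on HEL cells (Homo sapiens) for cytotoxicity; on this read-out higher numbers stand for lower toxicity in this test and lower numbers for higher toxicity in this test. The value of compound 1 is a limit of the assay and not a number (the limit of >= 133000 nM in this assay, at which 1 of the 3 values shown sits). Compound 2 differs from compound 1 by one change, (methyl in place of 3,4-dihydroxy-5-(hydroxymethyl)oxolan-2-yl on an aromatic nitrogen), and the size of this step, a step that the limit leaves unreadable from compound 1 to compound 2, cannot be read. Compound 3 differs from compound 1 by ethyl in place of hydrogen on a saturated chain carbon, six bonds along the chain from a triple-bonded carbon, and here the step is readable: an at least 2.7-fold lower number from compound 1 to compound 3 (0.43 log units; beyond the scatter). Within this set compound 3 gives the lowest number, while compound 2 gives a higher one.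

Compound 4, `CCCCCCCCC#Cc1cc2cn(C)c(=O)nc2o1`, has not yet been measured. It differs from compound 3 by methyl in place of 3,4-dihydroxy-5-(hydroxymethyl)oxolan-2-yl on an aromatic nitrogen, the same change as from compound 1 to compound 2, made at the same place. Because a step that the limit leaves unreadable from compound 1 to compound 2 leaves the size of that step unreadable, the expectation for compound 4 rests mainly on the fact that compound 2 gives a number rather than a limit and that compound 3 gives 49000 nM. A small step is expected for compound 4, a 1.3-fold higher number from compound 3 to compound 4 (0.12 log units; within the scatter), with the direction uncertain. Compound 4 is estimated at 65000 nM, with a likely range from 25000 nM to 160000 nM.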

Compound 4, minimum cytotoxic concentration: > 175000 nM
Compound 4 ended at the assay's limit; the forecaster's own chance of this, stated with the estimate: 15%; at least 2.6-fold (0.43 log units) between middle value and limit.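

In this assay, methyl in place of 3,4-dihydroxy-5-(hydroxymethyl)oxolan-2-yl on an aromatic nitrogen, made on the chain lengthened by ethyl, gives an at least 3.5-fold higher number from compound 3 to compound 4 (0.55 log units; beyond the scatter), so on this chain the change clearly moves the read-out towards lower toxicity in this test. The value of compound 4 is a limit of the assay and not a number, so the true size of this step stays open on the upper side: the limit of > 175000 nM in this assay, at which 1 of the 4 values shown sits.

This one readable step does not show that the change carries over from one chain to the other with the same size, because the same change from compound 1 to compound 2 cannot be read, nor can the step from compound 2 to compound 4, and compound 1 also stands at a limit: the limit of >= 133000 nM in this assay, at which 1 of the 4 values shown sits.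

The compounds shown leave open whether an ethyl or a benzyl group on the same nitrogen would behave as methyl does, and so whether the shift follows from the loss of the 3,4-dihydroxy-5-(hydroxymethyl)oxolan-2-yl group alone. They also leave open whether a longer chain than that of compound 3 would lower the number further, with either group on the nitrogen.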